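Para-substituent swap on the anilide of the shared core

The source may hold more compounds than are shown below. What is called first, only, known or untested is meant among the compounds shown, and "the series" means these compounds.

Measured so far:
compound 1 `N#Cc1ccc(NC(=O)c2cn(Cc3c(F)cccc3F)c3ccc(=O)[nH]c3c2=O)cc1`: 96 nM
compound 2 `O=C(O)Cc1ccc(NC(=O)c2cn(Cc3c(F)cccc3F)c3ccc(=O)[nH]c3c2=O)cc1`: 176 nM

Within the data shown here, in an in vitro assay on Sf21 cells for inhibition of high affinity 3',5'-cyclic-AMP phosphodiesterase 7A (Homo sapiens), read by scintillation proximity assay, with a stated time of 30 min (a lower number here means a stronger inhibitor, a higher number a weaker inhibitor), compound 2 gives the higher of the two numbers, and the only neighbour is compound 1. Among the measured compounds shown here, the one measured step, a 1.8-fold higher number from compound 1 to compound 2 (0.26 log units; within the scatter), does not reach beyond the scatter, so the two compounds cannot be ordered on these data.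

Compound 3 `NS(=O)(=O)c1ccc(NC(=O)c2cn(Cc3c(F)cccc3F)c3ccc(=O)[nH]c3c2=O)cc1` is not yet measured. It differs from compound 2 in one place: sulfamoyl in place of carboxymethyl on an aromatic carbon. For the measured compounds named here, the only step that bears on this change is the step from compound 1 to compound 2, which also exchanges the group on that aromatic carbon and which stayed within the scatter. Going by the values given here, with a single such step in hand, and no step that moved the number beyond the scatter, the expectation for compound 3 is a number of the same order as compound 2 and compound 1, with no step beyond the scatter in either direction.

The estimate for compound 3 in this assay is 130 nM, with a range from 50 nM to 350 nM, which means an expected step of a 1.4-fold lower number from compound 2 to compound 3 (0.13 log units; within the scatter).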

Compound 3, half-maximal inhibitory concentration: 34 nM
Compound 3: the middle estimate sits 3.8-fold (0.58 log units) above what was measured; the whole stated range lies above it.
By their numbers in this assay, from the lowest: compound 3; then compounds 1 and 2 (each within the scatter of the next).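

In this assay, the group on this aromatic carbon, para to a large group, now moves the number beyond the scatter: sulfamoyl in place of carboxymethyl gives a 5.2-fold lower number from compound 2 to compound 3 (0.71 log units; beyond the scatter), and sulfamoyl in place of cyano gives a 2.8-fold lower number from compound 1 to compound 3 (0.45 log units; beyond the scatter), so the position is not indifferent to what it carries, which the first pair could not show. Carboxymethyl and sulfamoyl match in heavy-atom count and neither brings a ring, so that count does not sort these two groups, although they differ in their atoms and in the hydrogen-bond acceptors counted. Nothing measured here accounts for the lower number with sulfamoyl.

Going by these compounds, it remains open which part of sulfamoyl goes with the lower number, as a sulfamoyl whose nitrogen carries a methyl group, a methylsulfonyl group or a carboxylic acid set directly on the ring would help to separate. On these data alone, all three compounds share one core and one position, so whether sulfamoyl gives the same kind of step elsewhere on that aromatic ring or on another core also remains open.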